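The source may hold more compounds than are shown below. What is called first, only, known or untested is meant among the compounds shown, and "the series" means these compounds.

Compound 1 `O=C(O)c1cn(C2CC2)c2cc(N3CCCC3)c(F)cc2c1=O`: 38 ug/mL
Compound 2 `COc1c(N2CCCC2)c(F)cc2c(=O)c(C(=O)O)cn(C3CC3)c12`: 150 ug/mL

In a functional assay on V79 cells (Cricetulus griseus) for cytotoxicity, read by colony formation (a lower number here means a stronger inhibitor, a higher number a weaker inhibitor), compound 2 has the higher of the two numbers, at 150 ug/mL. Compound 3 `O=C(O)c1cn(C2CC2)c2c(C(F)(F)F)c(N3CCCC3)c(F)cc2c1=O` differs from it by trifluoromethyl in place of methoxy on an aromatic carbon. Among the measured compounds shown here, the only measured step that bears on this change is a 3.9-fold higher number from compound 1 to compound 2 (0.60 log units; beyond the scatter), which is modest and beyond the scatter. It involved methoxy in place of hydrogen at the same aromatic carbon. For the measured compounds named here, no measured compound carries trifluoromethyl, so that step is only a rough guide. Going by the values given here, compound 3 also lacks the methoxy, so a small move toward a lower number in this assay is expected, no larger than that step and possibly within the scatter. The estimate means an expected 1.7-fold lower number from compound 2 to compound 3 (0.22 log units; within the scatter). For compound 3 the estimated value is 90 ug/mL, with an expected range from 30 ug/mL to 270 ug/mL.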

Compound 3, half-maximal inhibitory concentration: 280 ug/mL
The estimate for compound 3 lay 3.1-fold (0.49 log units) below the measured number; measured number above the stated range.
By their numbers in this assay, from the lowest: compound 1; then compounds 2 and 3 (each within the scatter of the next).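

In this assay, trifluoromethyl on the aromatic carbon ortho to a fused ring gives a 7.4-fold higher number from compound 1 to compound 3 (0.87 log units; beyond the scatter) and this lies beyond the scatter, so a second group at this position now moves the number the same way as methoxy did. Exchanging the two groups gives a 1.9-fold higher number from compound 2 to compound 3 (0.27 log units; within the scatter) and this lies within the scatter, so the assay does not separate methoxy from trifluoromethyl here. Since trifluoromethyl has no oxygen and no hydrogen-bond acceptor, neither is needed at this position for the number to stay beyond the scatter of compound 1. No measurement shown here accounts for this result. On these data alone, whether an amine, a hydroxyl group or a longer chain on this carbon would also leave the number beyond the scatter of compound 1 remains open. So does whether the same holds with piperazine in place of the pyrrolidin-1-yl group.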